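The source may hold more compounds than are shown below. What is called first, only, known or untested is meant among the compounds shown, and "the series" means these compounds.

Within the data shown here, in an ADME assay on the whole organism (plasma) for metabolic stability, with Rattus norvegicus as the target (a higher number here means that the compound lasts longer, a lower number that the compound disappears faster), compound 2 `CC1(C)CCC(C)(C)c2cc(COC(=O)c3ccc(C(=O)O)cc3)ccc21` gives 2.3 h, the only exact number so far. Compound 1 `CC(OC(=O)c1ccc(C(=O)O)cc1)c1ccc2c(c1)C(C)(C)CCC2(C)C` gives > 6 h, which is a limit of the assay and not a number. Compound 3 `C[C@H](OC(=O)c1ccc(C(=O)O)cc1)c1ccc2c(c1)C(C)(C)CCC2(C)C` has methyl in place of hydrogen on a saturated chain carbon bound to an aromatic carbon and an oxygen next to a carbonyl group, compared with compound 2. Counted atom by atom, the change is methyl in place of hydrogen on a saturated chain carbon bound to an aromatic carbon and an oxygen next to a carbonyl group. Among the measured compounds shown here, the one measured step that bears on this is an at least 2.6-fold lower number from compound 1 to compound 2 (0.41 log units; beyond the scatter), the same change run the other way, so a rise of similar size or more is expected in this assay. The estimated change is a 3.0-fold higher number from compound 2 to compound 3 (0.48 log units; beyond the scatter). For compound 3 the expected half-life is 7 h, with an estimated range from 3.5 h to 14 h.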

Compound 3, half-life: > 24 h
Compound 3: a limit, no number (the forecaster's own chance of this, stated with the estimate: 55%); middle value at least 3.4-fold (0.53 log units) from the limit.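

At the saturated chain carbon bound to an aromatic carbon and an oxygen next to a carbonyl group, this assay now shows methyl in place of hydrogen with one configuration drawn, and the result is an at least 10-fold higher number from compound 2 to compound 3 (1.01 log units; beyond the scatter). Going by these compounds, compound 3 gives > 24 h, which is a limit and not a number, so the full size of this step remains unknown. Compound 1 and compound 3 have the same atoms and bonds, yet the step between them cannot be read, and the role of configuration at this carbon stays unsettled; one difference between them is worth noting: the fact that one of compounds 1 and 3 is drawn with a defined configuration and the other without, at the place where they differ

The compounds shown leave open how the opposite configuration at this carbon would behave when drawn on its own. They also leave open whether an ethyl group at the same carbon would give a similar rise.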